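The source may report more compounds than this note shows. Statements on the series, on what has been measured and on what is new or still open speak of the compounds shown alone.

Compound 1 `Cc1ccc(CCSc2nc3c(c(=O)n(C)c(=O)n3C)n2C)cc1` is a thioether whose chain ends in a 4-methylphenyl group. In an assay on microsomes for inhibition of Amine oxidase [flavin-containing] A (Homo sapiens), read by fluorescence and spectrophotometry, with a stated time of 20 min (on this read-out lower numbers stand for stronger inhibition and higher numbers for weaker inhibition), compound 1 gives 125000 nM, the lowest of the three numbers, though within the scatter of both neighbours. Within the data shown here, compound 2 `Cn1c(=O)c2c(nc([S+]([O-])CCc3ccc(Cl)cc3)n2C)n(C)c1=O` gives 203000 nM and compound 3 `Cn1c(=O)c2c(nc([S+]([O-])Cc3ccccc3)n2C)n(C)c1=O` gives 250000 nM; the only measured step, a 1.2-fold higher number from compound 2 to compound 3 (0.09 log units; within the scatter), concerns a sulfoxide rather than the thioether of compound 1 and shows no change beyond the scatter. Compound 4 `Cn1c(=O)c2c(nc(SCCCc3cccc(Cl)c3)n2C)n(C)c1=O` carries 3-chlorobenzyl in place of 4-methylphenyl on a saturated chain carbon, two bonds along the chain from a sulfur. Among the measured compounds shown here, no measured step matches this change; the one step available suggests that swapping the aryl end leaves the read-out about where it was, so compound 4 is expected to give 150000 nM, between 60000 nM and 400000 nM, a step of a 1.2-fold higher number from compound 1 to compound 4 (0.08 log units; within the scatter) that is estimated to stay within the scatter.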

Compound 4, half-maximal inhibitory concentration: 3530 nM
For compound 4 the middle estimate is 42-fold (1.63 log units) above the measured one, and the stated range ends above it.
By their numbers in this assay, from the lowest: compound 4; then compounds 1, 2 and 3 (each within the scatter of the next).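

In this assay, swapping the aryl end of the chain gives a 35-fold lower number from compound 1 to compound 4 (1.55 log units; beyond the scatter). This shows that the read-out can respond strongly to a change at this place, which the earlier values, all within the scatter of their neighbours, did not show. Nothing available explains the size of this step.

This one step alters the ring substituent and the chain together, so the compounds shown leave open which alteration carries it. A 3-methylbenzyl or 3-chlorophenyl group at this place would help separate them.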